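A few compounds are considered here, and "the series" means these few. Any claim that something is new, unique, unknown or untested is made for them only; others in the source may bear on it.

In a functional assay on KARPAS-422 cells (Homo sapiens) for inhibition, read by luminescence and CellTiter-Glo, with a stated time of 14 days (on this read-out lower numbers stand for stronger inhibition of growth and higher numbers for weaker inhibition of growth), compound 2 (`O=C1c2ccccc2CN1c1cnc(NCc2c(F)ccc3c2CCO3)n2cnnc12`) gives 19 nM and compound 1 (`CN(c1ncco1)c1cnc(NCc2c(F)ccc3c2CCO3)n2cnnc12`) gives 21 nM on the same read-out, so the two values lie within the scatter of each other. Compound 3 (`CN(c1ccn(C)n1)c1cnc(NCc2c(F)ccc3c2CCO3)n2cnnc12`) differs from compound 2 in one place, on an aromatic carbon of the shared core, with a group of 8 heavy atoms (5 carbon, 3 nitrogen; one five-membered aromatic ring with 2 hetero atoms) in place of a group of 10 heavy atoms (8 carbon, 1 nitrogen, 1 oxygen; one five-membered non-aromatic ring with 1 hetero atom, one six-membered aromatic ring of carbon only), on an aromatic carbon as the counted difference. The entering group is methyl(1-methyl-1H-pyrazol-3-yl)amino. Within the data shown here, one measured step bears on this change: a 1.1-fold lower number from compound 1 to compound 2 (0.04 log units; within the scatter) at that same place. That step joins a group holding a five-membered aromatic ring with 2 hetero atoms to the group that now leaves, and the entering group also holds such a ring. No change beyond the scatter is therefore expected, and the expected step is a 1.1-fold higher number from compound 2 to compound 3 (0.02 log units; within the scatter) in this assay as well. Compound 3 is estimated at 20 nM with 8 nM to 55 nM as the expected range.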

Compound 3, concentration for 50% growth inhibition: 27 nM
Beside the measured number, compound 3's estimate is 1.4-fold (0.13 log units) below it; the range from low to high includes it.
By their numbers in this assay, from the lowest: compounds 2, 1 and 3 (each within the scatter of the next).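

In this assay the aromatic carbon of the shared core now carries a third group with no step beyond the scatter, as the exchange of the fused lactam-type group for methyl(1-methyl-1H-pyrazol-3-yl)amino gives a 1.4-fold higher number from compound 2 to compound 3 (0.15 log units; within the scatter) at this place. Among these compounds, compound 3 also adds the first comparison in which only the ring on the amine nitrogen changes, with 1-methyl-1H-pyrazol-3-yl in place of 1,3-oxazol-2-yl giving a 1.3-fold higher number from compound 1 to compound 3 (0.11 log units; within the scatter) in the same assay. No supporting measurement bears on these results.

All three groups reach the core through a nitrogen, which leaves open how a group joined through carbon or oxygen, such as phenyl or methoxy, would read here. Whether the methyl on the amine nitrogen of compound 1 and compound 3 matters also stays open, as no secondary amine is shown.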